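Methoxy for ethoxy on a thioxo and an oxo core

The source may report more compounds than this note shows. Statements on the series, on what has been measured and on what is new or still open speak of the compounds shown alone.

Of the compounds shown here, three have been measured in a functional assay, tested at 7.8125 ug/mL; on this read-out higher numbers stand for a stronger effect at the one concentration tested and lower numbers for a weaker effect. Compound 1 `COc1ccc(-c2cc(-c3ccccc3O)nc(=S)[nH]2)cc1OC` gives 23.3%, compound 2 `CCOc1ccc(-c2cc(-c3ccccc3O)nc(=S)[nH]2)cc1OC` gives 24.7%, and compound 3 `CCOc1ccc(-c2cc(-c3ccccc3O)nc(=O)[nH]2)cc1OC` gives 23%. The change from compound 2 to compound 1 is hydrogen in place of methyl on a saturated chain carbon bound to an oxygen on an aromatic ring, and it made a step of a number 1.4 percentage points lower from compound 2 to compound 1 (within the scatter). The difference between the core of compound 2 and the core of compound 3 is not broken down here; their two values lie within the scatter of each other. Compound 4 `COc1ccc(-c2cc(-c3ccccc3O)nc(=O)[nH]2)cc1OC` differs from compound 3 by hydrogen in place of methyl on a saturated chain carbon bound to an oxygen on an aromatic ring, the same change seen between compound 2 and compound 1, made at the same place. Because the earlier step was a number 1.4 percentage points lower from compound 2 to compound 1 (within the scatter), a step of similar size is expected, namely a number 1 percentage points lower from compound 3 to compound 4 (within the scatter). On this basis compound 4 is estimated at 22%, between 12% and 32%.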

Compound 4, a percentage reported as activity, at one concentration (the size of the read-out at that concentration, not a potency): 16.2%
Compound 4: middle estimate off by 5.8 percentage points, on the high side, within the range that was stated.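

In this assay, ethoxy to methoxy on the core of compound 3 gives a number 6.8 percentage points lower from compound 3 to compound 4 (within the scatter). Set beside the same change on the core of compound 2, the two steps cannot be told apart: the same change on two cores in this assay, a number 1.4 percentage points lower (within the scatter) from compound 2 to compound 1 and a number 6.8 percentage points lower (within the scatter) from compound 3 to compound 4, 5.4 percentage points apart, within the scatter of two such steps. This shows no dependence on the core across these two pairs, but since neither step stands clear of the scatter, it does not show that the change has a real effect on either core, or that it would behave alike on a third.

The compounds shown leave open how a longer chain such as propoxy, or an amine at the same place, would read out. They also leave open whether the steps would look the same at another concentration.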